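Phenyl for Pentyl on the Acylguanidine Nitrogen of Compound 2

This account rests on a few compounds, and the source may have more. Where it says the series, first, only, none or still open, it means among the compounds named here.

The series is built around an acylguanidine carrying an aminothiazole-bearing side chain. In a functional assay on HEK293T cells for agonist activity at histamine H2 receptor (Homo sapiens), read by beta-arrestin recruitment (a lower number here means a smaller maximal response, a higher number a larger maximal response), compound 1 `CCCNC(=O)/N=C(\N)Nc1cccc(-c2csc(N)n2)c1` gives "not determined" (no result reported), so it has no result to show. Compound 2 `CCCCCNC(=O)/N=C(\N)NCCCc1sc(N)nc1C` and compound 3 `N/C(=N\C(=O)NCc1ccccc1)NC1CCc2nc(N)sc2C1` were both tested in this assay; compound 2 gives 0.15, and compound 3 gives 0.31. Compound 2 thus stands lowest of the two numbers, with compound 3 above it by a step beyond the usual scatter. Compound 4 `Cc1nc(N)sc1CCCN/C(N)=N/C(=O)Nc1ccccc1` has not yet been measured. It differs from compound 2 in one place: phenyl in place of pentyl on an amide-type nitrogen, a difference that, cut one bond further out, reads pentylamino to anilino. For the measured compounds named here, no step between two measured compounds follows this same change, so the account can rest only on what compound 2 and compound 3 show. A moderate rise is expected, since the larger value belongs to compound 3, which carries an aromatic ring near this nitrogen, 0.31. The expected step in this assay from compound 2 to compound 4 is a number 0.10 higher from compound 2 to compound 4 (within the scatter). Compound 4 is therefore estimated at 0.25, within a range from 0.1 to 0.45.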

Compound 4, intrinsic activity: the largest response reached, as a fraction of the reference agonist's: 0.25
Estimate against measurement, compound 4: no gap at the digits printed, and the stated range covers the measured number.
By their numbers in this assay, from the lowest: compounds 2, 4 and 3 (each within the scatter of the next, the first and the last beyond it).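

In this assay, the first step read at this position is phenyl in place of pentyl on the amide-type nitrogen, which gives a number 0.10 higher from compound 2 to compound 4 (within the scatter). An open chain and an aromatic ring of carbon only can therefore stand on this nitrogen without the maximal response moving beyond the scatter, so this single change does not separate compound 2 from compound 4. Nothing measured here bears on what lies behind this step.

Going by these compounds, it remains open whether a cyclohexyl group, a shorter chain such as ethyl, or a phenyl ring carrying a methoxy group on this nitrogen would give a step beyond the scatter. On these data alone, it also remains open whether pentyl to phenyl would give a similar step on a different side chain, such as that of compound 3.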